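Swapping an Aromatic Group for an Octyl Chain

The compounds below may be only part of what the source reports. "The series", "measured", "known", "first", "only" and "open" are said of these compounds alone.

In a functional assay on A549 cells (Homo sapiens) for antiproliferative activity, read by MTT assay (a higher number here means a weaker inhibitor, a lower number a stronger inhibitor), compound 1 (`CC(=O)c1ccc(-n2cc(COc3ccc(/C=C/C(=O)c4cc5c(cc4O)OC(C)(C)CC5)cc3)nn2)cc1`) gives 66300 nM. Within the data shown here, the only other measured compound, compound 2 (`CCc1ccccc1-n1cc(COc2ccc(/C=C/C(=O)c3ccc4c(c3O)CCC(C)(C)O4)cc2)nn1`), gives 112000 nM. These two values lie within the usual scatter of each other, so neither compound can be ranked above the other.

Compound 3 (`CCCCCCCCn1cc(COc2ccc(/C=C/C(=O)c3cc4c(cc3O)OC(C)(C)CC4)cc2)nn1`) keeps the core of compound 1 and changes one group: octyl in place of 4-acetylphenyl on an aromatic nitrogen of a five-membered aromatic ring with 3 nitrogen (octyl in place of 4-acetylphenyl on an aromatic nitrogen).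

Among the measured compounds shown here, no measured pair shows what a swap of this kind does, since compound 1 and compound 2 differ in more than one place. The expectation therefore stays anchored on compound 1 at 66300 nM, with no direction favoured and no change expected beyond the scatter. The expected move in this assay is a 1.1-fold lower number from compound 1 to compound 3 (0.04 log units; within the scatter), a small one. Compound 3 is estimated at 60000 nM, with an expected range of 20000 nM to 160000 nM.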

Compound 3, half-maximal inhibitory concentration: 50800 nM
Compound 3: middle estimate off by 1.2-fold (0.07 log units), on the high side; low and high end bracket the measured number.
By their numbers in this assay, from the lowest: compounds 3, 1 and 2 (each within the scatter of the next, the first and the last beyond it).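

In this assay, octyl in place of 4-acetylphenyl on an aromatic nitrogen gives a 1.3-fold lower number from compound 1 to compound 3 (0.12 log units; within the scatter), so the two compounds cannot be told apart. The swap takes away a six-membered aromatic ring of carbon only, together with a double bond outside aromatic rings and a hydrogen-bond acceptor, and puts in a chain with no ring, so this one pair shows that, with this core, an aromatic ring on this nitrogen is not needed for the reading to stay within the scatter. Nothing measured here explains why two such different groups read alike.

Going by these compounds, what a shorter chain such as butyl, or an octyl chain ending in an amine or a carboxylic acid, would do on this nitrogen remains open, since a single pair cannot show how the reading depends on chain length or on a group at the chain's end. Also open, on these data alone, is whether the same swap would read the same way on the core of compound 2.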